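Sulfur-linked side chain variations on the shared core

The source may hold more compounds than are shown below. What is called first, only, known or untested is meant among the compounds shown, and "the series" means these compounds.

Compound 1 `Cc1cc(Nc2cc(-c3ccccc3)[nH]n2)n2nc(SCCCc3ccccc3)nc2n1` carries a phenethyl group on a saturated chain carbon bound to a sulfur. In a functional assay on MGC-803 cells (Homo sapiens) for inhibition, read by MTT assay, with a stated time of 72 h (on this read-out lower numbers stand for stronger inhibition and higher numbers for weaker inhibition), compound 1 gives 6510 nM, the second highest of the three numbers recorded so far. Compound 2 `Cc1cc(Nc2cc(-c3ccccc3)[nH]n2)n2nc(SCc3cccc4ccccc34)nc2n1` gives 3120 nM in this assay, and compound 3 `C=CCSc1nc2nc(C)cc(Nc3cc(-c4ccccc4)[nH]n3)n2n1` gives 17200 nM. Two steps start from compound 1: a 2.1-fold lower number from compound 1 to compound 2 (0.32 log units; beyond the scatter), and a 2.6-fold higher number from compound 1 to compound 3 (0.42 log units; beyond the scatter). The pair of compounds 2 and 3 shows a 5.5-fold higher number from compound 2 to compound 3 (0.74 log units; beyond the scatter). Both steps point the same way: an aromatic ring directly on the chain carbon bound to a sulfur goes with a lower number, a small vinyl group with a higher one.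

Compound 4 `COc1ccc(CSc2nc3nc(C)cc(Nc4cc(-c5ccccc5)[nH]n4)n3n2)cc1` is not yet measured. Its change from compound 1 is 4-methoxyphenyl in place of phenethyl on a saturated chain carbon bound to a sulfur. Like compound 2, compound 4 places an aromatic ring directly on the chain carbon, so a modest lowering is expected, of a size near a 2.1-fold lower number from compound 1 to compound 2 (0.32 log units; beyond the scatter) or somewhat less. The expected step is a 1.6-fold lower number from compound 1 to compound 4 (0.19 log units; within the scatter). For compound 4 the estimate in this assay is 4200 nM, within 2000 nM to 9000 nM.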

Compound 4, half-maximal inhibitory concentration: 3170 nM
Beside the measured number, compound 4's estimate is 1.3-fold (0.12 log units) above it, within the range that was stated.
By their numbers in this assay, from the lowest: compounds 2 and 4 (each within the scatter of the next); then compound 1; then compound 3.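

In this assay, a single-ring aromatic group on the saturated chain carbon bound to a sulfur is enough for the lowering seen with compound 2: the step is a 2.1-fold lower number from compound 1 to compound 4 (0.31 log units; beyond the scatter) and, against the vinyl group, a 5.4-fold lower number from compound 3 to compound 4 (0.73 log units; beyond the scatter) in the same direction. For the compounds shown here, the fused naphthalen-1-yl group cannot be told apart from 4-methoxyphenyl here, with a 1.0-fold higher number from compound 2 to compound 4 (0.01 log units; within the scatter) as the step, so across these four compounds an aromatic ring directly on that carbon goes with the lower numbers and no compound goes against this. No evidence on hand explains these steps.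

Open, going by these compounds, is how far substitution on the ring matters, for example with a 4-aminophenyl or a 4-carboxyphenyl group on the same chain carbon. Also open, on these data alone, is whether the lower numbers hold with a longer chain carrying the 4-methoxyphenyl group.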